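The source may report more compounds than this note shows. Statements on the series, on what has been measured and on what is new or still open speak of the compounds shown alone.

In a functional assay on KM12 cells (Homo sapiens) for inhibition (a higher number here means a weaker inhibitor of growth, a lower number a stronger inhibitor of growth), compound 1 `NC(=O)c1cc(Cl)ccc1NC(=O)COc1ccccc1` gives 2130 nM and compound 2 `NC(=O)c1cc(I)ccc1NC(=O)COc1ccccc1` gives 308 nM. Among the measured compounds shown here, compound 2 thus holds the lower of the two numbers measured so far, and it is the starting point for the next comparison. Compound 3 `COc1ccc(NC(=O)COc2ccccc2)c(C(N)=O)c1` has not yet been measured. It carries methoxy in place of iodo on an aromatic carbon, (methoxy in place of iodo on an aromatic carbon). For the measured compounds named here, the change falls at the same place as the only measured step, which bears directly on it. That step, a 6.9-fold lower number from compound 1 to compound 2 (0.84 log units; beyond the scatter), was modest in size but beyond the scatter, and it came with iodo in place of chloro. It shows that the number in this assay responds to the group at this place. Going by the values given here, no measured compound carries methoxy, however, so the direction rests on that single pair and remains uncertain. A step of similar size toward a higher number is expected, and the estimated step is a 7.1-fold higher number from compound 2 to compound 3 (0.85 log units; beyond the scatter). For compound 3 the expected value is 2200 nM, with an estimated range from 700 nM to 7000 nM.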

Compound 3, concentration for 50% growth inhibition: 388 nM
Estimate against measurement, compound 3: 5.7-fold (0.75 log units) above; the whole stated range lies above it.
By their numbers in this assay, from the lowest: compounds 2 and 3 (each within the scatter of the next); then compound 1.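

In this assay, methoxy in place of iodo on this aromatic carbon, meta to a carbamoyl group and para to a large group, gives a 1.3-fold higher number from compound 2 to compound 3 (0.10 log units; within the scatter), so these two groups cannot be told apart here, although methoxy enters with 1 hydrogen-bond acceptor and iodo leaves with 0. Methoxy in place of chloro at the same place gives a 5.5-fold lower number from compound 1 to compound 3 (0.74 log units; beyond the scatter), which shows that the earlier gain seen with iodo is not confined to that one group: among the three groups shown, chloro alone stands apart with the higher number, and iodo and methoxy go together. Nothing available explains why these two different groups give numbers within the scatter of each other, or why chloro differs from both.

The compounds shown leave open how far this place tolerates other kinds of group, such as an amine or a carboxylic acid. They also leave open whether a longer chain, such as ethoxy, would keep the number of methoxy or move it beyond the scatter.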